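Butyl in place of a halogenated phenyl on the sulfonamide

The source may hold more compounds than are shown below. What is called first, only, known or untested is meant among the compounds shown, and "the series" means these compounds.

Measured so far:
compound 1, `Cc1cc(S(=O)(=O)Nc2ccc3c(c2)CCN(C)CC3)ccc1-c1ccc(Cl)cc1`, 5.01 nM
compound 2, `CN1CCc2ccc(NS(=O)(=O)c3ccc(-c4ccc(F)c(Cl)c4)cc3)cc2CC1`, 7.94 nM

Both compounds were tested in an assay on isolated protein for displacement of a labelled ligand from 5-hydroxytryptamine receptor 6 (Homo sapiens), read by radioligand binding; a lower number here means a stronger inhibitor, a higher number a weaker inhibitor. Compound 1 gives 5.01 nM, and compound 2 gives 7.94 nM. The two numbers lie within the scatter of each other, so nothing separates compound 2 from compound 1 on this evidence. Among the measured compounds shown here, no step between the two measured compounds is recorded, since they differ in more than one place.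

Compound 3, `CCCCc1ccc(S(=O)(=O)Nc2ccc3c(c2)CCN(C)CC3)cc1`, has not been measured in this assay. It differs from compound 2 in one place: butyl in place of 3-chloro-4-fluorophenyl on an aromatic carbon, para to a large group. For the measured compounds named here, no measured pair shows what such a change does here, so the expectation rests on the change itself and on the narrow spread of the two known values. A step from compound 2 to compound 3 of a 6.3-fold higher number from compound 2 to compound 3 (0.80 log units; beyond the scatter) is expected, towards a higher number. Compound 3 is therefore estimated at 50 nM, within a range of 8 nM to 400 nM.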

Compound 3, inhibition constant: 1.26 nM
Estimate against measurement, compound 3: 40-fold (1.60 log units) above, and the stated range ends above it.
By their numbers in this assay, from the lowest: compound 3; then compounds 1 and 2 (each within the scatter of the next).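

In this assay, the place on an aromatic carbon para to a large group does not need a ring for a low number: butyl in place of 3-chloro-4-fluorophenyl gives a 6.3-fold lower number from compound 2 to compound 3 (0.80 log units; beyond the scatter) and so improves binding rather than losing it. The group that enters has no ring and fewer heavy atoms than the group that leaves, and neither has hydrogen-bond donors or acceptors, so neither the ring nor its chlorine and fluorine are required at this place for a low number. Nothing measured here accounts for the direction or size of this step.

With a single chain at this place, the compounds shown leave open whether propyl, pentyl or the branched tert-butyl would give a similar number, and whether plain phenyl would already account for part of the step. Going by these compounds, it also remains open whether a butyl chain ending in an amine or a carboxylic acid would be tolerated at this place, and whether butyl would give a similar step on the methyl-bearing ring of compound 1.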